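Cyclohexyl in Place of tert-Butyl: Compound 3 to Compound 4

The compounds below may be only part of what the source reports. "The series", "measured", "known", "first", "only" and "open" are said of these compounds alone.

Among the measured compounds shown here, compound 3 `CCOC(=O)C1CCCN(C(=O)CN2CN(c3ccccc3)C3(CCN(C(=O)c4ccc(C(C)(C)C)cc4)CC3)C2=O)C1` gives 8200 nM in an assay on HEK293 cells for displacement of a labelled ligand from NPC1-like intracellular cholesterol transporter 1 (Homo sapiens) (on this read-out lower numbers stand for stronger inhibition and higher numbers for weaker inhibition), the second highest of the three numbers measured so far. Compound 1 `O=C(CN1CN(c2ccccc2)C2(CCN(C(=O)c3ccc(C4CCCCC4)cc3)CC2)C1=O)NCCCCO` gives 10300 nM, a gap within the scatter, while compound 2 `O=C(CN1CN(c2ccccc2)C2(CCN(C(=O)c3ccc(C4CCCCC4)cc3)CC2)C1=O)NCCO` gives 2000 nM, a gap beyond it. For the measured compounds named here, the one measured step, a 5.2-fold lower number from compound 1 to compound 2 (0.71 log units; beyond the scatter), concerns the chain on the amide nitrogen and tells nothing about the aromatic substituent. Compound 4 `CCOC(=O)C1CCCN(C(=O)CN2CN(c3ccccc3)C3(CCN(C(=O)c4ccc(C5CCCCC5)cc4)CC3)C2=O)C1` differs from compound 3 by cyclohexyl in place of tert-butyl on an aromatic carbon. Going by the values given here, compounds 1 and 2 carry cyclohexyl and compound 3 tert-butyl, but their other parts differ as well, so no measured step bears directly on this change. The chemist therefore expects no step beyond the scatter in this assay, a 1.4-fold lower number from compound 3 to compound 4 (0.14 log units; within the scatter). Compound 4 is estimated at 6000 nM, within 2500 nM to 20000 nM.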

Compound 4, half-maximal inhibitory concentration: 4200 nM
Estimate against measurement, compound 4: 1.4-fold (0.15 log units) above; the measured number falls inside the stated range.
By their numbers in this assay, from the lowest: compound 2; then compounds 4, 3 and 1 (each within the scatter of the next, the first and the last beyond it).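

In this assay, the change on an aromatic carbon para to a large group now has a direct reading: a 2.0-fold lower number from compound 3 to compound 4 (0.29 log units; within the scatter), so cyclohexyl in place of tert-butyl stays within the scatter. On the carbonyl carbon, 3-(ethoxycarbonyl)piperidin-1-yl gives opposite directions against the two hydroxylated amines: a 2.1-fold higher number from compound 2 to compound 4 (0.32 log units; beyond the scatter), yet a 2.5-fold lower number from compound 1 to compound 4 (0.39 log units; beyond the scatter). Nothing available accounts for these steps.

The compounds shown leave open how a phenyl or a methoxy group would read at this aromatic carbon. They also leave open whether a carboxylic acid in place of the ethoxycarbonyl would shift the number.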